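Trading Morpholine for a Difluorophenoxy Group on the Sulfonyl

This account rests on a few compounds, and the source may have more. Where it says the series, first, only, none or still open, it means among the compounds named here.

In an assay on liver for inhibition of sterol O-acyltransferase 1 (Rattus norvegicus), using microsomes (a higher number here means a weaker inhibitor, a lower number a stronger inhibitor), compound 1 `CC(C)c1cccc(C(C)C)c1NC(=O)NS(=O)(=O)N(C(C)C)C(C)(C)C` gives 140 nM, while compound 2 `CC(C)c1cccc(C(C)C)c1NS(=O)(=O)NC(=O)NC(c1ccccc1)c1ccccc1` gives 30000 nM. Compound 3 `CC(C)c1cccc(C(C)C)c1OC(=O)NS(=O)(=O)N1CCOCC1` is reported only as a limit of this assay, > 100000 nM, which is the limit of > 100000 nM in this assay, at which 1 of the 3 values shown sits. Compound 4 `CC(C)c1cccc(C(C)C)c1OC(=O)NS(=O)(=O)Oc1ccc(F)cc1F` differs from compound 3 in one place: 2,4-difluorophenoxy in place of morpholin-4-yl on a sulfonyl sulfur. Within the data shown here, no step between two measured compounds covers a change of this kind, so any expectation rests on the weak standing of compound 3 alone. The step expected here is an at least 1.6-fold lower number from compound 3 to compound 4 (0.22 log units; that floor lies within the scatter), which points toward a stronger inhibitor but stays within the usual scatter, so no real direction is claimed. Compound 4 is therefore estimated at 60000 nM, with a likely range from 8000 nM to 200000 nM.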

Compound 4, half-maximal inhibitory concentration: > 50000 nM
Compound 4: only a limit was reported; the forecaster's own chance of this, stated with the estimate: 50%; the middle value is on the limit's open side.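

Among these compounds, compound 3 and compound 4 are both reported only as limits in this assay, so no step between them can be read. The compounds shown leave open which of the two, if either, is the stronger inhibitor.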